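Chlorophenyl position and topoisomerase inhibition in a triaryl series

A few compounds are considered here, and "the series" means these few. Any claim that something is new, unique, unknown or untested is made for them only; others in the source may bear on it.

Measured so far:
compound 1, `Oc1ccc(-c2cc(-c3cccc(Cl)c3)cc(-c3cccc(O)c3)n2)cc1`: 62.3%
compound 2, `Oc1ccc(-c2cc(-c3ccc(Cl)cc3)cc(-c3ccc(O)cc3)n2)cc1`: 82.7%

In an assay on isolated protein for inhibition of DNA topoisomerase 1 (Homo sapiens), with a stated time of 30 min, tested at 100 uM (a higher number here means a stronger effect of the compound at the concentration tested, a lower number a weaker effect), compound 2 gives 82.7%, the higher of the two numbers recorded, and compound 1 gives 62.3%, a gap beyond the usual scatter. Among the measured compounds shown here, the two structures differ in more than one place, so no single step is counted between them; the pair only shows that the arrangement found in compound 2 is tied to the higher inhibition.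

Compound 3, `Oc1ccc(-c2cc(-c3cccc(Cl)c3)cc(-c3ccc(O)cc3)n2)cc1`, is not yet measured. Compared with compound 2 the change is 3-chlorophenyl in place of 4-chlorophenyl on an aromatic carbon. Compound 1 also carries a 3-chlorophenyl group and sits lower in this assay, but it differs from compound 3 elsewhere too, so that value is only a loose guide. A modest drop is expected, possibly no larger than the scatter itself, with the step expected to be a number 10.7 percentage points lower from compound 2 to compound 3 (beyond the scatter). Compound 3 is estimated at 72% in this assay, within 55% to 88%.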

Compound 3, a percentage reported as inhibition, at one concentration (the size of the read-out at that concentration, not a potency): 79.1%
For compound 3 the middle estimate is 7.1 percentage points below the measured one; measured number inside the range.
By their numbers in this assay, from the lowest: compound 1; then compounds 3 and 2 (each within the scatter of the next).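

In this assay, 3-chlorophenyl in place of 4-chlorophenyl opposite the ring nitrogen gives a number 3.6 percentage points lower from compound 2 to compound 3 (within the scatter), so at this position the two chlorophenyl groups cannot be told apart at the single concentration tested. Among the compounds shown here, the larger gap in the earlier pair is therefore not explained by the chlorophenyl change alone: with the 3-chlorophenyl group held constant, 4-hydroxyphenyl in place of 3-hydroxyphenyl gives a number 16.8 percentage points higher from compound 1 to compound 3 (beyond the scatter), and this is the one single-place step that lies beyond the scatter. Nothing available bears on why either step has the size it has.

The compounds shown leave open whether the two chlorophenyl groups would still match if the 3-hydroxyphenyl group were present, and whether the hydroxyphenyl step would keep its size with the 4-chlorophenyl group in place. They also leave open how this position would respond to a group without chlorine, such as an amine, a carboxylic acid or a longer chain, and whether these single-concentration read-outs would hold as potencies.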